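Swapping an Ester Oxygen for an Anilide Nitrogen

A few compounds are considered here, and "the series" means these few. Any claim that something is new, unique, unknown or untested is made for them only; others in the source may bear on it.

Measured compounds:
Compound 1 `COC(=O)/C=C/c1ccc(OS(=O)(=O)c2ccc(Cl)cc2)c(OC)c1`: 99500 nM
Compound 2 `CCCCS(=O)(=O)Oc1ccc(/C=C/C(=O)OCC(C)C)cc1OC`: 63800 nM
Compound 3 `COc1cc(/C=C/C(=O)Nc2cccc(C)c2)ccc1OS(=O)(=O)c1ccc(Cl)cc1`: 73500 nM

All three compounds share one core and were tested in a toxicity assay on L02 cells (Homo sapiens) for cytotoxicity, read by MTT assay, with a stated time of 24 h; a higher number here means that more compound is tolerated, a lower number that less compound is tolerated. The three numbers lie within the usual scatter of one another; the value of compound 2 sits at the low end, yet it cannot be told apart from compound 3 or from compound 1 on these numbers alone.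

Compound 4 `CCCCS(=O)(=O)Oc1ccc(/C=C/C(=O)Nc2ccccc2C)cc1OC` has not yet been measured. It differs from compound 2 in one place: (2-methylphenyl)amino in place of isobutoxy on a carbonyl carbon. For the measured compounds named here, the change is a close relative of the one that separates compound 1 from compound 3, where a (3-methylphenyl)amino group stands in place of methoxy on the carbonyl carbon. That step gave a 1.4-fold lower number from compound 1 to compound 3 (0.13 log units; within the scatter), a shift too small to count.

Going by the values given here, with only that one comparable step to lean on, no movement beyond the scatter is expected for compound 4 in this assay. The step from compound 2 to compound 4 is therefore estimated at a 1.1-fold lower number from compound 2 to compound 4 (0.03 log units; within the scatter). Compound 4 is expected to give about 60000 nM, with a likely range from 30000 nM to 120000 nM.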

Compound 4, half-maximal cytotoxic concentration: 56100 nM
Beside the measured number, compound 4's estimate is 1.1-fold (0.03 log units) above it; the measured number falls inside the stated range.
By their numbers in this assay, from the lowest: compounds 4, 2, 3 and 1 (each within the scatter of the next).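

In this assay, a 1.1-fold lower number from compound 2 to compound 4 (0.06 log units; within the scatter) gives a second case of an ester group giving way to a methylphenylamino group on the carbonyl carbon, and this step also stays within the scatter. The earlier case, a 1.4-fold lower number from compound 1 to compound 3 (0.13 log units; within the scatter), involved a small methoxy group, a different methylphenylamino group and a different remainder of the molecule, whereas this one starts from the larger isobutoxy group. Across these two pairs, then, the exchange of oxygen-linked chain for nitrogen-linked aromatic ring, which also adds a hydrogen-bond donor, leaves the tolerated concentration without a readable change, although no information is available on why that is so.

The compounds shown leave open whether a quite different group on this carbonyl carbon, such as a free carboxylic acid or a morpholine amide, would move the number beyond the scatter. They also cannot settle whether the place of the methyl group on the ring matters, since compound 3 and compound 4 differ in more than one place, and a pair differing only in that methyl group would be needed to answer it.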